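The compounds below may be only part of what the source reports. "The series", "measured", "known", "first", "only" and "open" are said of these compounds alone.

Compound 2 `O=C(Nc1c(C(O)(C(F)(F)F)C(F)(F)F)ccc2ccccc12)c1cccc(C(F)(F)F)c1` has been measured in an assay on LtK cells with ATP-sensitive inward rectifier potassium channel 11 (Homo sapiens) as the target (a lower number here means that less compound is needed, a higher number that more compound is needed for the effect), where compound 2 gives 84 nM. Compound 1 `O=C(CC1CCCC1)Nc1c(C(O)(C(F)(F)F)C(F)(F)F)ccc2ccccc12` gives 81 nM, so compound 2 stands level with it within the scatter; the step of a 1.0-fold higher number from compound 1 to compound 2 (0.02 log units; within the scatter) shows that swapping the whole group on the carbonyl left the number essentially unchanged. Compound 3 `COc1cccc(C(=O)Nc2c(C(O)(C(F)(F)F)C(F)(F)F)ccc3ccccc23)c1` differs from compound 2 by methoxy in place of trifluoromethyl on an aromatic carbon. Within the data shown here, no measured step covers this exact change, and the one step known stayed within the scatter. Compound 3 is therefore expected to shift by a 1.1-fold higher number from compound 2 to compound 3 (0.03 log units; within the scatter) in this assay, nothing beyond the scatter. Compound 3 is estimated at 90 nM, between 40 nM and 200 nM.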

Compound 3, half-maximal effective concentration: 185 nM
Estimate against measurement, compound 3: 2.1-fold (0.31 log units) below; low and high end bracket the measured number.
By their numbers in this assay, from the lowest: compounds 1 and 2 (each within the scatter of the next); then compound 3.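

Replacing trifluoromethyl with methoxy gives a 2.2-fold higher number from compound 2 to compound 3 (0.34 log units; beyond the scatter) in this assay, so the group at this place on the phenyl ring can move the number, which the level pair of compound 1 and compound 2 could not show. The change from cyclopentylmethyl to 3-methoxyphenyl is also no longer neutral, with a 2.3-fold higher number from compound 1 to compound 3 (0.36 log units; beyond the scatter) as a modest step. Nothing available explains this shift. On these data alone, it remains open whether a methyl, a chlorine or an amine at this same place would follow methoxy or trifluoromethyl.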